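This account rests on a few compounds, and the source may have more. Where it says the series, first, only, none or still open, it means among the compounds named here.

Compound 1 `CC[C@H](C)[C@@H]1C(=O)N[C@H](C2Cc3ccccc3C2)C(=O)N1[C@@H](C(=O)N1CCOCC1)c1cnc(C)cc1C` gives 0.0501 nM in an assay on isolated protein for displacement of a labelled ligand from Oxytocin receptor (Homo sapiens); a lower number here means a stronger inhibitor, a higher number a weaker inhibitor.
Compound 2 `Cc1ccc([C@H](C(=O)N(C)C)N2C(=O)[C@@H](C3Cc4ccccc4C3)NC(=O)[C@H]2CC(C)C)cn1` gives 1.59 nM in this assay.

Of these two numbers, compound 1 has the lower one; compound 2 sits well above it, and the gap between them lies beyond the usual scatter. Compound 1 and compound 2 differ in more than one place, so that gap cannot be tied to any single change. Compound 3 `CC[C@H](C)[C@@H]1C(=O)N[C@H](C2Cc3ccccc3C2)C(=O)N1[C@@H](C(=O)N1CCOCC1)c1cc(C)cnc1C` has not yet been measured. It is built from the same atoms as compound 1, joined differently: 2,5-dimethylpyridin-3-yl in place of 4,6-dimethylpyridin-3-yl on a saturated chain carbon bound to an amide-type nitrogen in a ring and a carbonyl carbon. Shifting the methyl groups on the pyridine ring is a small rearrangement, yet no measured pair shows what such a swap does here, so the direction is uncertain. A modest loss, rather than none, is the expectation. The step from compound 1 to compound 3 in this assay is therefore expected to be a 3.0-fold higher number from compound 1 to compound 3 (0.48 log units; beyond the scatter). For compound 3 the estimate in this assay is 0.15 nM, with a range from 0.03 nM to 1 nM.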

Compound 3, inhibition constant: 0.794 nM
For compound 3 the middle estimate is 5.3-fold (0.72 log units) below the measured one; measured number inside the range.
By their numbers in this assay, from the lowest: compound 1; then compounds 3 and 2 (each within the scatter of the next).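

In this assay, rearranging the same atoms on the pyridine ring gives a 16-fold higher number from compound 1 to compound 3 (1.20 log units; beyond the scatter). The earlier compounds shown here could not show this, as compound 1 and compound 2 differ in more than one place. The group on a saturated chain carbon bound to an amide-type nitrogen in a ring and a carbonyl carbon is therefore sensitive to how its ring is arranged, even though 4,6-dimethylpyridin-3-yl and 2,5-dimethylpyridin-3-yl have identical atom counts, and no measurement available here explains the loss.

Still open, as far as these compounds go, is whether one methyl group, both methyl groups or the ring nitrogen accounts for the step. A pyridine ring with a single methyl group, or a plain phenyl ring, would help separate these possibilities.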